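A few compounds are considered here, and "the series" means these few. Any claim that something is new, unique, unknown or untested is made for them only; others in the source may bear on it.

Of the compounds shown here, two have been tested in a functional assay on MGC-803 cells (Homo sapiens) for inhibition, read by MTT assay, with a stated time of 72 h (on this read-out higher numbers stand for weaker inhibition and lower numbers for stronger inhibition), and both share the same core with a bromobenzyl thioether attached to it. Compound 1 `Cc1cc(Nc2cc(-c3ccc(Cl)cc3)[nH]n2)n2nc(SCc3ccc(Br)cc3)nc2n1` carries a 4-chlorophenyl group on its pyrazole arm, and in this assay compound 1 gives 2780 nM. Compound 2 `Cc1cc(Nc2ccn(Cc3nc(C)c4ccccc4n3)n2)n2nc(SCc3ccc(Br)cc3)nc2n1` carries a different arm, and in this assay compound 2 gives 960 nM. Of the two numbers, compound 1 stands at the higher one, meaning weaker inhibition, and the gap to compound 2 lies beyond the usual scatter. Among the measured compounds shown here, no pair of measured compounds differs in only one place, so no single measured step is available to guide an expectation.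

Compound 3 `Cc1cc(Nc2cc(-c3ccccc3)[nH]n2)n2nc(SCc3ccc(Br)cc3)nc2n1` is compound 1 with one change: hydrogen in place of chloro on an aromatic carbon. The chloro is removed from the 4-chlorophenyl group, leaving a plain phenyl. For the measured compounds named here, with no measured step of this kind at hand, the expectation is a modest move toward a higher number, though one that may well fall within the scatter. Compound 3 is therefore estimated at 4000 nM, within a range of 1500 nM to 11000 nM, which corresponds to an expected step of a 1.4-fold higher number from compound 1 to compound 3 (0.16 log units; within the scatter).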

Compound 3, half-maximal inhibitory concentration: 1110 nM
The estimate for compound 3 lay 3.6-fold (0.56 log units) above the measured number, outside the stated range (below it).
By their numbers in this assay, from the lowest: compounds 2 and 3 (each within the scatter of the next); then compound 1.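

In this assay, taking the chloro off the 4-chlorophenyl group gives a 2.5-fold lower number from compound 1 to compound 3 (0.40 log units; beyond the scatter). Among the compounds shown here, this is the first measured step that changes only one place, and it shows that the chloro on this aromatic carbon is not needed for inhibition: the plain phenyl of compound 3 does better than the 4-chlorophenyl of compound 1, by more than repeat measurements would normally scatter. No measurement at hand says why the number falls when this one atom is replaced by hydrogen.

As far as these compounds go, with only chloro and hydrogen to compare at this carbon, it remains open whether the lower number belongs to hydrogen in particular or whether other small groups, such as fluoro, methyl, methoxy or an amine, would give a similar or an even lower number. From the compounds shown here alone, it is also open whether the same change would have a similar effect with a different group on the sulfur in place of the bromobenzyl, since this single step was read with that one group in place.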